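Adding an ester-bearing benzyl group to compound 2

This account rests on a few compounds, and the source may have more. Where it says the series, first, only, none or still open, it means among the compounds named here.

Measured compounds and their values:
- compound 1 `Nc1nc(N)c(CCCN(Cc2ccc(NC(CCC(=O)O)C(=O)O)cc2)c2cc(F)cc(F)c2[N+](=O)[O-])c(O)n1`: > 100000 nM (a limit of the assay)
- compound 2 `Nc1nc(N)c(CCCNc2cc(F)c(F)cc2[N+](=O)[O-])c(O)n1`: > 100000 nM (a limit of the assay)
- compound 3 `Nc1nc(N)c(CCCN(Cc2ccc(NC(CCC(=O)O)C(=O)O)cc2)c2cc(F)c([N+](=O)[O-])cc2[N+](=O)[O-])c(O)n1`: 44000 nM

All three were tested in a functional assay on CCRF-CEM cells (Homo sapiens) for cytotoxicity, in the absence of a further agent; on this read-out lower numbers stand for stronger inhibition and higher numbers for weaker inhibition. Compound 2 carries the shared core joined through a short chain to a nitrogen on the aromatic ring, and for compound 2 the value > 100000 nM is a limit, not a number. Compound 1 also stopped at a limit, which is the limit of > 100000 nM in this assay, at which 2 of the 3 values shown sit. Compound 3 is the only one of the three with an actual number, 44000 nM, and it is still weak.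

Compound 4 `COC(=O)c1ccc(CN(CCCc2c(N)nc(N)nc2O)c2cc(F)c(F)cc2[N+](=O)[O-])cc1` is not yet measured. It differs from compound 2 in one place: 4-(methoxycarbonyl)benzyl in place of hydrogen on a nitrogen on an aromatic ring. Compound 1 carries a related benzyl group on the same kind of nitrogen and remained at the limit, so this change gives little reason to expect a large gain. In this assay the step from compound 2 to compound 4 is expected to be small and uncertain in direction, at most a modest improvement, as an at least 1.6-fold lower number from compound 2 to compound 4 (0.22 log units; that floor lies within the scatter).

For compound 4 the estimated result is 60000 nM, with a range from 15000 nM to 200000 nM.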

Compound 4, half-maximal inhibitory concentration: 55000 nM
For compound 4 the middle estimate is 1.1-fold (0.04 log units) above the measured one; the range from low to high includes it.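

In this assay, placing 4-(methoxycarbonyl)benzyl in place of hydrogen on this nitrogen gives an at least 1.8-fold lower number from compound 2 to compound 4 (0.25 log units; that floor lies within the scatter). Compound 2 gives > 100000 nM, which is a limit of the assay and not a number, so only the smallest possible size of this step is known, and its true size could be larger. What the earlier compounds did not show is that this nitrogen on the aromatic ring can carry a substituent of this size while the compound still gives a real number, leaving compound 4 outside the group that stops at: the limit of > 100000 nM in this assay, at which 2 of the 4 values shown sit.

The compounds shown do not reveal which part of the new group matters, since none of them differs from compound 4 only at the ester or only in the ring attached to the benzyl carbon. A plain benzyl group, or a carboxylic acid in place of the methyl ester, would separate the contribution of the ring from that of the ester, while compounds 1 and 3 differ from compound 4 in more than one place and cannot settle this.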